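Hexyl to cyclohexyl on the amine of compound 2

A few compounds are considered here, and "the series" means these few. Any claim that something is new, unique, unknown or untested is made for them only; others in the source may bear on it.

Measured so far:
- Compound 1 `CCCCCCNc1nc(-c2ccccc2)nc2c1nnn2Cc1ccccc1`: 13.2 nM
- Compound 2 `CCCCCCNc1nc(-c2ccccc2)nc2c1nnn2Cc1ccccc1Cl`: 31 nM
- Compound 3 `CCCCCCNc1nc(-c2ccccc2)nc2c1nnn2Cc1ccccc1C(F)(F)F`: "not determined" (no result reported)

All three compounds share one core and were tested in an assay on Cerebral cortex for displacement of a labelled ligand from adenosine receptor A1 (Bos taurus); a lower number here means a stronger inhibitor, a higher number a weaker inhibitor. In this assay compound 1 gives 13.2 nM. Compound 2 carries a chloro in place of hydrogen on an aromatic carbon of the benzyl group, and in this assay compound 2 gives 31 nM; the change is a 2.3-fold higher number from compound 1 to compound 2 (0.37 log units; beyond the scatter). Compound 2 therefore stands as the higher of the two numbers, with compound 1 nearest. For compound 3 no number is reported.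

The next compound, compound 4 `Clc1ccccc1Cn1nnc2c(NC3CCCCC3)nc(-c3ccccc3)nc21`, keeps the chloro-substituted benzyl group of compound 2 and alters the other end of the molecule: cyclohexyl in place of hexyl on a nitrogen on an aromatic ring. Among the compounds with values here, neither measured step touches this part of the structure; the only step known concerns the benzyl ring, so nothing measured bears directly on swapping a chain for a ring on the amine. Without a matching step, the expectation is a change within the scatter in either direction, and compound 4 is estimated at 25 nM, in the range 8 nM to 80 nM, meaning an expected step of a 1.2-fold lower number from compound 2 to compound 4 (0.09 log units; within the scatter).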

Compound 4, inhibition constant: 34 nM
Compound 4: middle estimate off by 1.4-fold (0.13 log units), on the low side; measured number inside the range.
By their numbers in this assay, from the lowest: compound 1; then compounds 2 and 4 (each within the scatter of the next).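

In this assay, putting cyclohexyl in place of hexyl on the nitrogen gives a step of a 1.1-fold higher number from compound 2 to compound 4 (0.04 log units; within the scatter), so the two compounds cannot be told apart. Within the data shown here, this is the first information about this end of the molecule, since the earlier step concerned only the benzyl group: with the chloro-substituted benzyl group held fixed, the open hexyl chain and the six-membered ring of carbon, each with 6 heavy atoms, give readings within the usual scatter of each other. Nothing available here explains why the two groups read alike.

Going by these compounds, it remains open whether hexyl and cyclohexyl would also read alike alongside the unsubstituted benzyl group of compound 1, as a result obtained with one benzyl group need not carry over to another. Also open, on these data alone, is how this nitrogen would respond to a group of a different size or kind, such as a shorter butyl chain, a smaller cyclopentyl ring or a flat phenyl ring.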